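A few compounds are considered here, and "the series" means these few. Any claim that something is new, unique, unknown or untested is made for them only; others in the source may bear on it.

Compound 1 `CCc1cccc(Nc2nccc(-c3ccco3)n2)c1` in a functional assay for inhibition, with Homo sapiens as the target (on this read-out lower numbers stand for stronger inhibition and higher numbers for weaker inhibition), gives 9700 nM
Compound 2 `CCc1cccc(Nc2nccc(-c3ccncc3)n2)c1` in this assay gives 10600 nM

Compound 2 holds the highest of the two numbers; its nearest neighbour is compound 1, and the step of a 1.1-fold higher number from compound 1 to compound 2 (0.04 log units; within the scatter) lies within the scatter. Compound 3 `CCc1cccc(Nc2nccc(-c3ccsc3)n2)c1` differs from compound 2 by thiophen-3-yl in place of pyridin-4-yl on an aromatic carbon. Among the measured compounds shown here, the one measured step bears on this only loosely: a 1.1-fold higher number from compound 1 to compound 2 (0.04 log units; within the scatter) shows that a furan-2-yl and a pyridin-4-yl group at this carbon give numbers within the scatter of each other. No step beyond the scatter is therefore expected in this assay. Compound 3 is estimated at 9500 nM, with a range from 4500 nM to 20000 nM. The expected step of a 1.1-fold lower number from compound 2 to compound 3 (0.05 log units; within the scatter) stays within the scatter.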

Compound 3, half-maximal inhibitory concentration: 1100 nM
Beside the measured number, compound 3's estimate is 8.6-fold (0.94 log units) above it, outside the stated range (below it).
By their numbers in this assay, from the lowest: compound 3; then compounds 1 and 2 (each within the scatter of the next).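

Thiophen-3-yl sets this position apart from the two earlier groups in this assay with a 9.6-fold lower number from compound 2 to compound 3 (0.98 log units; beyond the scatter) and with an 8.8-fold lower number from compound 1 to compound 3 (0.95 log units; beyond the scatter) while furan-2-yl and pyridin-4-yl stay within the scatter of each other. The position therefore responds to the choice of aromatic ring, and the five-membered furan-2-yl of compound 1 shows that ring size alone does not settle the number. Nothing at hand accounts for these steps.
Open, going by these compounds, is whether thiophen-2-yl matches thiophen-3-yl here, and whether a methyl group or an amine on the thiophene ring keeps the lower number.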